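This account rests on a few compounds, and the source may have more. Where it says the series, first, only, none or still open, it means among the compounds named here.

Measured so far in a physicochemical assay for solubility; on this read-out lower numbers stand for lower solubility and higher numbers for higher solubility:
compound 1 `O=C(O)c1ccc(C(=O)/C(=C\c2ccc(Cl)c([N+](=O)[O-])c2)SCc2ccc(Cl)cc2)cc1` gives < 1000 ug/mL (a limit)
compound 2 `O=C(O)c1ccc(C(=O)/C(=C\c2ccc(Br)c([N+](=O)[O-])c2)SCc2ccc(Cl)cc2)cc1` gives < 1000 ug/mL (a limit)

Going by these compounds, compound 1 has only the limit < 1000 ug/mL as its value, so its exact place on the scale is unknown. Compound 2 likewise has only a limit, < 1000 ug/mL as reported. All the evidence so far is the limit of < 1000 ug/mL in this assay, at which 2 of the 2 values shown sit, and no more.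

Compound 3 `O=C(O)c1ccc(C(=O)/C(=C\c2ccc(Cl)c([N+](=O)[O-])c2)SCc2ccc(F)cc2)cc1` keeps the core of compound 1 and changes one group, (fluoro in place of chloro on an aromatic carbon), fluoro in place of chloro. Going by the values given here, the one measured step, a step that the two limits leave unreadable from compound 1 to compound 2, also exchanges one halogen for another, bromo in place of chloro, but gives no size to carry over. No step beyond the usual scatter is therefore expected in this assay, in either direction. The expected step is a step that the limit leaves unreadable from compound 1 to compound 3 as estimated. Compound 3 is estimated at 600 ug/mL with an expected range of 150 ug/mL to 1000 ug/mL and will probably be reported as a limit too.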

Compound 3, solubility: < 1000 ug/mL
Compound 3: a limit, no number (the forecaster's own chance of this, stated with the estimate: 85%); the middle value does not contradict the limit.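

Going by these compounds alone, compound 3, like compound 1, is reported only as a limit in this assay, so no step between the two can be read. The compounds shown leave open where each one sits on the scale and whether either halogen exchange alters the read-out: the limit of < 1000 ug/mL in this assay, at which 3 of the 3 values shown sit.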